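Swapping a pyrazole for a pyrrole on a nucleoside core

The source may hold more compounds than are shown below. What is called first, only, known or untested is meant among the compounds shown, and "the series" means these compounds.

Of the compounds shown here, three that share one nucleoside core have been measured in a functional assay on HL-60 cells (Homo sapiens) for inhibition; on this read-out lower numbers stand for stronger inhibition and higher numbers for weaker inhibition. Compound 1 `Cc1ccsc1-c1ncnc2c1ncn2C1O[C@H](CO)[C@@H](O)[C@H]1O` carries a 3-methylthiophen-2-yl group and gives 4500 nM. Compound 2 `OC[C@H]1OC(n2cnc3c(-c4cc[nH]n4)ncnc32)[C@H](O)[C@@H]1O` carries a 1H-pyrazol-3-yl group and gives 1170 nM, the lowest number of the three. Compound 3 `OC[C@H]1OC(n2cnc3c(-c4ccco4)ncnc32)[C@H](O)[C@@H]1O` carries a furan-2-yl group and gives 2700 nM. The step of a 3.8-fold lower number from compound 1 to compound 2 (0.59 log units; beyond the scatter) is modest but beyond the scatter, the step of a 2.3-fold higher number from compound 2 to compound 3 (0.36 log units; beyond the scatter) is also modest, and the step of a 1.7-fold lower number from compound 1 to compound 3 (0.22 log units; within the scatter) lies within the scatter.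

Compound 4 `OC[C@H]1OC(n2cnc3c(-c4cc[nH]c4)ncnc32)[C@H](O)[C@@H]1O` has not been measured. It differs from compound 2 in one place: 1H-pyrrol-3-yl in place of 1H-pyrazol-3-yl on an aromatic carbon. The hydrogen-bond donor stays, the hydrogen-bond acceptor goes. The two measured steps away from compound 2 both led to higher numbers, yet neither removed only the acceptor, so the bearing on this change is indirect. A modest weakening is expected for compound 4, a step of a 2.1-fold higher number from compound 2 to compound 4 (0.33 log units; beyond the scatter), because the entering group resembles the five-membered rings of compound 1 and compound 3 in lacking the pyrazole pattern that in compound 2 gave 1170 nM. Compound 4 is therefore estimated at 2500 nM, with a likely range from 1000 nM to 6000 nM.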

Compound 4, half-maximal inhibitory concentration: 3200 nM
Compound 4: the middle estimate sits 1.3-fold (0.11 log units) below what was measured; low and high end bracket the measured number.
By their numbers in this assay, from the lowest: compound 2; then compounds 3, 4 and 1 (each within the scatter of the next).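

In this assay, replacing one ring nitrogen of the 1H-pyrazol-3-yl group with carbon gives a 2.7-fold higher number from compound 2 to compound 4 (0.44 log units; beyond the scatter), so on this aromatic carbon, a change of one ring atom is enough to move the number beyond the scatter, even though the hydrogen-bond donor stays. The 1H-pyrrol-3-yl group also does not set compound 4 apart from the other two analogues: a 1.2-fold higher number from compound 3 to compound 4 (0.07 log units; within the scatter) and a 1.4-fold lower number from compound 1 to compound 4 (0.15 log units; within the scatter) are both within the scatter, leaving compound 2 as the only one of the four with a number clearly separated from the rest. No measurement here explains why the ring nitrogen makes this difference.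

The compounds shown leave open whether the lower number depends specifically on the 1H-pyrazol-3-yl group or could also be reached with an imidazole or a triazole ring. They also leave open whether the ring hydrogen of the pyrazole matters, a question that a methyl group on that ring nitrogen could test.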